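Pyridyl for methoxyphenyl on the fused core

A few compounds are considered here, and "the series" means these few. Any claim that something is new, unique, unknown or untested is made for them only; others in the source may bear on it.

Three members of the series have been run in a physicochemical assay for solubility (on this read-out lower numbers stand for lower solubility and higher numbers for higher solubility), and each result is a limit of the assay rather than a number. Compound 1 `CNC(=O)c1cc(C(=O)N[C@H]2[C@@H]3COC[C@@H]32)cc2c1OC[C@H]2c1ccccc1` gives >= 165 ug/mL, a limit. Compound 2 `CNC(=O)c1cc(C(=O)N[C@H]2CC[C@H](O)CC2)cc2c1OC[C@@]2(C)c1ccccc1` gives >= 161 ug/mL, likewise a limit. Compound 3 `CNC(=O)c1cc(C(=O)N[C@H]2[C@@H]3COC[C@@H]32)cc2c1OC[C@H]2c1cccc(OC)c1` gives >= 186 ug/mL, again a limit, so compound 3 stands at the upper end of what this assay reports, alongside the other two values that are also limits. Among the measured compounds shown here, the one single-point step among them, a step that the two limits leave unreadable from compound 1 to compound 3, cannot be read for size because both ends are limits.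

Compound 4 `CNC(=O)c1cc(C(=O)N[C@H]2[C@@H]3COC[C@@H]32)cc2c1OC[C@H]2c1cccnc1` differs from compound 3 by pyridin-3-yl in place of 3-methoxyphenyl on a saturated ring carbon. For the measured compounds named here, no measured step bears on this change directly, and the only related step is unreadable. Compound 3 already sits at a limit, so compound 4 is expected to be reported at a limit as well, with the value estimated at 190 ug/mL and a range of 120 ug/mL to 400 ug/mL. This corresponds to an expected step that the limit leaves unreadable from compound 3 to compound 4 in this assay, none beyond the scatter being anticipated.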

Compound 4, solubility: >= 104 ug/mL
Compound 4: a limit, no number; the forecaster's own chance of this, stated with the estimate: 80%; the middle value lies beyond the limit too.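

In this assay compound 4, like compound 1 and compound 3, is reported only as a limit, so the steps from compound 3 and compound 1 to compound 4 cannot be read. The compounds shown leave open whether pyridin-3-yl, 3-methoxyphenyl and phenyl on the saturated ring carbon differ at all in this assay.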